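Thiourea series: halogenated aryl replacing dimethylphenyl on the thiourea nitrogen

A few compounds are considered here, and "the series" means these few. Any claim that something is new, unique, unknown or untested is made for them only; others in the source may bear on it.

Compound 1 `CNC(=O)c1ccc(Oc2cccc(NC(=S)Nc3ccc(C)c(C)c3)c2)nc1` gives 67400 nM in a functional assay on PC-3 cells (Homo sapiens) for antiproliferative activity, read by MTT assay (on this read-out lower numbers stand for stronger inhibition and higher numbers for weaker inhibition), the highest of the three numbers recorded so far. Compound 2 `CNC(=O)c1ccc(Oc2cccc(NC(=S)Nc3ccc(F)c(F)c3)c2)nc1` gives 23100 nM and compound 3 `CNC(=O)c1ccc(Oc2cccc(NC(=S)Nc3ccc(F)cc3)c2)nc1` gives 32700 nM. The two steps away from compound 1 both lower the number: a 2.9-fold lower number from compound 1 to compound 2 (0.47 log units; beyond the scatter), and a 2.1-fold lower number from compound 1 to compound 3 (0.31 log units; beyond the scatter). Between the two fluorinated analogues the gap is small, a 1.4-fold higher number from compound 2 to compound 3 (0.15 log units; within the scatter).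

Compound 4 `CNC(=O)c1ccc(Oc2cccc(NC(=S)Nc3ccc(F)c(Cl)c3)c2)nc1` is not yet measured. Its change from compound 1 is 3-chloro-4-fluorophenyl in place of 3,4-dimethylphenyl on an amide-type nitrogen. Within the data shown here, this change resembles the one from compound 1 to compound 2, where the 3,4-dimethylphenyl also gave way to a ring bearing fluoro at both of the same positions, and the step there was beyond the scatter but modest. A step of similar size in the same direction is therefore expected, so that the estimated step is a 3.1-fold lower number from compound 1 to compound 4 (0.49 log units; beyond the scatter). Compound 4 is expected to give about 22000 nM, with a range of 9000 nM to 55000 nM.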

Compound 4, half-maximal inhibitory concentration: 18400 nM
Beside the measured number, compound 4's estimate is 1.2-fold (0.08 log units) above it; measured number inside the range.
By their numbers in this assay, from the lowest: compounds 4, 2 and 3 (each within the scatter of the next); then compound 1.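

With the 3-chloro-4-fluorophenyl group on the amide-type nitrogen, this assay gives a 3.7-fold lower number from compound 1 to compound 4 (0.56 log units; beyond the scatter) as the step, so a third halogenated ring also stands beyond the scatter from the 3,4-dimethylphenyl of compound 1. Chloro in place of hydrogen gives a 1.8-fold lower number from compound 3 to compound 4 (0.25 log units; within the scatter) and chloro in place of fluoro gives a 1.3-fold lower number from compound 2 to compound 4 (0.10 log units; within the scatter) as their steps, both within the scatter, so compounds 2, 3 and 4 cannot be ordered and the identity of the halogen on this ring is not resolved. No measurement offers an explanation for the separation of these rings from the ring of compound 1.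

Whether a halogen is needed at all remains open, since an unsubstituted phenyl and rings bearing methoxy or trifluoromethyl do not appear among these compounds. Also open, as far as these compounds go, is how bromo would compare with chloro and fluoro on this ring.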